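A few compounds are considered here, and "the series" means these few. Any claim that something is new, unique, unknown or untested is made for them only; others in the source may bear on it.

Measured so far in a functional assay on HeLa cells (Homo sapiens) for antiproliferative activity, with a stated time of 48 h (a lower number here means a stronger inhibitor, a higher number a weaker inhibitor), are two compounds:

- compound 1 `C=C(Br)C(=O)Nc1ccc(/C=C/C(=O)c2cccc(OC)c2)cc1` gives 700 nM
- compound 2 `Nc1ccc(/C=C/C(=O)c2ccccc2)cc1` gives 36000 nM

Compound 2 holds the higher of these two numbers, which makes it the weaker inhibitor, and its gap to compound 1 lies beyond the scatter. The two compounds differ in more than one place, so that gap cannot be pinned on any single change.

Compound 3 `COc1cccc(C(=O)/C=C/c2ccc(N)cc2)c1` is compound 2 with methoxy in place of hydrogen on an aromatic carbon, meta to a large group methoxy in place of hydrogen on an aromatic carbon and otherwise unchanged. Among the compounds with values here, no measured pair shows this change alone. Only a small step toward a lower number is therefore expected in this assay, possibly none beyond the scatter. The expected change is a 1.8-fold lower number from compound 2 to compound 3 (0.26 log units; within the scatter) on this estimate. Compound 3 is estimated at 20000 nM, with an expected range from 7000 nM to 50000 nM in this estimate.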

Compound 3, half-maximal inhibitory concentration: 33000 nM
Beside the measured number, compound 3's estimate is 1.7-fold (0.22 log units) below it, and the stated range covers the measured number.
By their numbers in this assay, from the lowest: compound 1; then compounds 3 and 2 (each within the scatter of the next).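

In this assay, methoxy in place of hydrogen on an aromatic carbon, meta to a large group, gives a 1.1-fold lower number from compound 2 to compound 3 (0.04 log units; within the scatter), so on this core compound 2 and compound 3 cannot be told apart. Compound 3 also differs from compound 1 in one place only: hydrogen in place of (1-bromoethenyl)carbonyl on the nitrogen gives a 47-fold higher number from compound 1 to compound 3 (1.67 log units; beyond the scatter), which places the large gap seen earlier with that change at the nitrogen and not with the methoxy. Nothing available here explains the size of either step.

Methoxy is the only group shown at the aromatic carbon, so it remains open whether an amine or a carboxylic acid there would shift the number beyond the scatter. On these data alone, it is also open whether a plain acetyl group on the nitrogen would give a number close to that of compound 1.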